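A Smaller Amine on the Same Core

The source may hold more compounds than are shown below. What is called first, only, known or untested is meant among the compounds shown, and "the series" means these compounds.

Compound 2 `CC(C)Sc1nnc(-c2c(CN3CCC(N4CCCC4)CC3)c3ccccc3n2C)n1-c1ccccc1` was measured in a physicochemical assay for lipophilicity (a higher number here means a more lipophilic compound, a lower number a more polar compound), and gives 5.16. Among the measured compounds shown here, compound 1 `CC(C)Sc1nnc(-c2c(CNCCN3CCCC3)c3cc(F)ccc3n2C)n1-c1ccccc1` is the only other measured compound; in this assay compound 1 gives 4.99, which lies within the usual scatter of the value for compound 2. Compound 3 `CC(C)Sc1nnc(-c2c(CNC3CC3)c3ccccc3n2C)n1-c1ccccc1` differs from compound 2 in one place: cyclopropylamino in place of 4-(pyrrolidin-1-yl)piperidin-1-yl on a saturated chain carbon bound to an aromatic carbon. For the measured compounds named here, no measured step of this kind is at hand. The expected step of a number 0.66 log units lower from compound 2 to compound 3 (beyond the scatter) is a decrease beyond the scatter. For compound 3 the estimated value is 4.5, with a range from 3.9 to 5.1.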

Compound 3, partition coefficient: 4.81
For compound 3 the middle estimate is 0.31 log units below the measured one, and the stated range covers the measured number.
By their numbers in this assay, from the lowest: compounds 3, 1 and 2 (each within the scatter of the next, the first and the last beyond it).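

In this assay, among the compounds shown here, cyclopropylamino in place of 4-(pyrrolidin-1-yl)piperidin-1-yl on a saturated chain carbon bound to an aromatic carbon gives a number 0.35 log units lower from compound 2 to compound 3 (beyond the scatter), the only step that can be read at this position on the shared core. The number at this position therefore does respond to the amine placed there, modestly but beyond the scatter. Nothing at hand gives a reason for this step.

The compounds shown leave open how the step divides over the group that leaves. Piperidin-1-yl alone or dimethylamino on the same carbon would speak to that.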